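Methylsulfonyl in place of isobutoxy on the pendant ring

The compounds below may be only part of what the source reports. "The series", "measured", "known", "first", "only" and "open" are said of these compounds alone.

The series shares one core carrying an ethyl ester, a methoxy group and a pendant aromatic ring. Compound 1 is `CCOC(=O)c1c(-c2cc(F)cc(OC)c2)[nH]c2cc(OC)ccc2c1=O`, compound 2 is `CCCCOc1cccc(-c2[nH]c3cc(OC)ccc3c(=O)c2C(=O)OCC)c1`, compound 3 is `CCOC(=O)c1c(-c2cccc(OCC(C)C)c2)[nH]c2cc(OC)ccc2c1=O`. In an ADME assay on BJ cells (Homo sapiens) for cytotoxicity, read by luminescence, with a stated time of 72 h (a higher number here means that more compound is needed for the effect, a lower number that less compound is needed), compound 1 gives > 21500 nM, a limit of the assay rather than a number. In this assay compound 2 likewise gives > 21500 nM, again a limit. Compound 3 gives > 21500 nM in this assay, also a limit, so compound 3 stands where every value of the series stands: the limit of > 21500 nM in this assay, at which 3 of the 3 values shown sit. Among the compounds with values here, the one step between measured compounds that differ in one place, a step that the two limits leave unreadable from compound 2 to compound 3, is therefore not readable.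

Compound 4 is `CCOC(=O)c1c(-c2cccc(S(C)(=O)=O)c2)[nH]c2cc(OC)ccc2c1=O`. It differs from compound 3 in one place: methylsulfonyl in place of isobutoxy on an aromatic carbon. Within the data shown here, no measured step bears on a change of this kind, and the only available step gives no size. With all three values at the limit, no direction can be read, and nothing in the data points to a step beyond the scatter. Compound 4 is expected to give 25000 nM in this assay, within 10000 nM to 60000 nM, most likely reported as a limit again. The estimated step that the limit leaves unreadable from compound 3 to compound 4 is expected to be essentially none.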

Compound 4, half-maximal effective concentration: > 21500 nM
Compound 4: a limit, no number; the forecaster's own chance of this, stated with the estimate: 85%; the middle value lies beyond the limit too.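

In this assay compound 4 gives > 21500 nM as a limit and not a number. The steps from compound 2 and compound 3 to compound 4 therefore cannot be read, and the series stays at one place: the limit of > 21500 nM in this assay, at which 4 of the 4 values shown sit.

The compounds shown leave open whether any change on the pendant ring shifts this cytotoxicity read-out, and in which direction.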